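The source may hold more compounds than are shown below. What is called first, only, known or untested is meant among the compounds shown, and "the series" means these compounds.

Compound 3 `O=c1nc(-c2ccccc2)c2cc(-c3ccccc3)ccc2[nH]1` was examined in an ADME assay on L6 cells (Rattus norvegicus) for cytotoxicity, read by fluorescence and resazurin assay, with a stated time of 72 h; on this read-out higher numbers stand for an effect only at larger amounts of compound and lower numbers for an effect already at smaller amounts. In this assay compound 3 gives > 50000 nM, which is a limit of the assay and not a number. Compound 1 `O=c1nc(-c2ccccc2)c2cc(-c3cccnc3)ccc2[nH]1` in this assay gives > 50000 nM, again only a limit. Compound 2 `Cc1ccncc1-c1ccc2[nH]c(=O)nc(-c3ccccc3)c2c1` in this assay gives > 50000 nM, likewise a limit. Since all three sit at the limit of > 50000 nM in this assay, at which 3 of the 3 values shown sit, the steps a step that the two limits leave unreadable from compound 1 to compound 2, a step that the two limits leave unreadable from compound 1 to compound 3 and a step that the two limits leave unreadable from compound 2 to compound 3 cannot be read, and compound 3 can be placed no more precisely than at the limit shared with compounds 1 and 2.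

Compound 4 `O=c1nc(-c2ccccc2)c2cc(-c3cccc(F)c3)ccc2[nH]1` has not yet been measured in this assay. It differs from compound 3 by fluoro in place of hydrogen on an aromatic carbon. Among the measured compounds shown here, none of the measured steps carries a readable size that bears on this change; they show only that three compounds of this core sit at the limit. The step that the limit leaves unreadable from compound 3 to compound 4 is therefore expected to be none beyond the scatter. Compound 4 is expected to give about 80000 nM in this assay, within 30000 nM to 250000 nM, most probably reported once more as a limit.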

Compound 4, half-maximal effective concentration: 23000 nM
For compound 4 the middle estimate is 3.5-fold (0.54 log units) above the measured one, outside the stated range (below it).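

In this assay, among the compounds shown here, fluoro in place of hydrogen on an aromatic carbon, meta to a large group, gives an at least 2.1-fold lower number from compound 3 to compound 4 (0.33 log units; beyond the scatter), which is the first readable step in this set and shows that this change at this position can move the read-out. Compound 4 also separates from the other two compounds, with an at least 2.1-fold lower number from compound 2 to compound 4 (0.33 log units; beyond the scatter) for 3-fluorophenyl in place of 4-methylpyridin-3-yl and an at least 2.1-fold lower number from compound 1 to compound 4 (0.33 log units; beyond the scatter) for 3-fluorophenyl in place of pyridin-3-yl. Compound 1, compound 2 and compound 3 all remain at a limit of the assay, not at a number: the limit of > 50000 nM in this assay, at which 3 of the 4 values shown sit.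

The steps among those three still cannot be read, and each step to compound 4 has only a lower bound on its size. From the compounds shown here alone, whether chloro, methoxy or an amine at this position would give a lower number than fluoro remains open.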